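Swapping fluoro for bromo in compound 1

This account rests on a few compounds, and the source may have more. Where it says the series, first, only, none or still open, it means among the compounds named here.

Compound 1 `Fc1ccc(C2=NN(c3nc(-c4ccc(Br)cc4)cs3)C(c3cccs3)C2)cc1` gives 220 nM in a functional assay on WM 266-4 cells (Homo sapiens) for antiproliferative activity, read by MTT assay, with a stated time of 48 h (a lower number here means a stronger inhibitor, a higher number a weaker inhibitor), the second highest of the three numbers recorded. Compound 2 `Fc1ccc(C2=NN(c3nc(-c4ccccc4)cs3)C(c3cccs3)C2)cc1` gives 170 nM, a step of a 1.3-fold lower number from compound 1 to compound 2 (0.11 log units; within the scatter); compound 3 `Fc1ccc(C2=NN(c3nc(-c4ccc(C(F)(F)F)cc4)cs3)C(c3cccs3)C2)cc1` gives 5120 nM, a step of a 23-fold higher number from compound 1 to compound 3 (1.37 log units; beyond the scatter), and a 30-fold higher number from compound 2 to compound 3 (1.48 log units; beyond the scatter). Compound 4 `Brc1ccc(C2=NN(c3nc(-c4ccc(Br)cc4)cs3)C(c3cccs3)C2)cc1` differs from compound 1 by bromo in place of fluoro on an aromatic carbon. All three measured steps alter the ring that carries bromo in compound 1, not the 4-fluorophenyl, so none bears directly on this change; the small step of a 1.3-fold lower number from compound 1 to compound 2 (0.11 log units; within the scatter) shows that a single halogen swap elsewhere moved little, while the large steps to compound 3 concern trifluoromethyl only. No step beyond the scatter is therefore expected, a 1.2-fold higher number from compound 1 to compound 4 (0.07 log units; within the scatter). Compound 4 is estimated at 260 nM, range 100 nM to 700 nM.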

Compound 4, half-maximal inhibitory concentration: 13000 nM
Compound 4: middle estimate off by 50-fold (1.70 log units), on the low side; measured number outside the range, above it.
By their numbers in this assay, from the lowest: compounds 2 and 1 (each within the scatter of the next); then compound 3; then compound 4.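

Changing 4-fluorophenyl to 4-bromophenyl gives a 59-fold higher number from compound 1 to compound 4 (1.77 log units; beyond the scatter), so this position is sensitive to a swap of one halogen for another. The step from the other ring, a 1.3-fold lower number from compound 1 to compound 2 (0.11 log units; within the scatter), therefore does not carry over to this position. No evidence on the cause of the step at this position is available.

On these data alone, it remains open whether hydrogen, chloro, methoxy or an amine at this position would stay close to compound 1 or fall away like compound 4. Also open, as far as these compounds go, is whether the same swap has a similar effect on compound 2.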